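Cyclopentyl for the ester chain on the quaternary nitrogen

This account rests on a few compounds, and the source may have more. Where it says the series, first, only, none or still open, it means among the compounds named here.

compound 1 `CCN1CCc2c(sc(NC(=O)Nc3ccc4ccccc4c3)c2C(N)=O)C1`: 1780 nM
compound 2 `CC(C)(C)OC(=O)CCC[N+]1(C)CCc2c(sc(NC(=O)Nc3ccc(Cl)cc3)c2C(N)=O)C1`: 250 nM
compound 3 `NC(=O)c1c(NC(=O)Nc2ccc(Cl)cc2)sc2c1CCN(CC1CCCC1)C2`: 1830 nM

In a functional assay (strain AB) with Danio rerio as the target, read by microscopy, with a stated time of 1 h (a lower number here means that less compound is needed, a higher number that more compound is needed for the effect), compound 2 gives the lowest of the three numbers, and both compound 1 and compound 3 lie beyond the scatter above it. Compound 4 `C[N+]1(CC2CCCC2)CCc2c(sc(NC(=O)Nc3ccc(Cl)cc3)c2C(N)=O)C1` differs from compound 2 by cyclopentyl in place of 2-(tert-butoxycarbonyl)ethyl on a saturated chain carbon bound to an amine nitrogen in a ring. Among the measured compounds shown here, no pair of measured compounds shows this change on its own, so the direction rests on little. Compound 3 also carries the cyclopentyl, and in this assay compound 3 gives 1830 nM, but compound 3 differs from compound 2 in more than one place. A moderate rise is therefore expected, a 2.4-fold higher number from compound 2 to compound 4 (0.38 log units; beyond the scatter), though it may stay within the scatter. For compound 4 the estimate is 600 nM, with a range from 150 nM to 2500 nM.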

Compound 4, half-maximal effective concentration: 200 nM
Compound 4: middle estimate off by 3.0-fold (0.48 log units), on the high side; the measured number falls inside the stated range.
By their numbers in this assay, from the lowest: compounds 4 and 2 (each within the scatter of the next); then compounds 1 and 3 (each within the scatter of the next).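

In this assay, cyclopentyl in place of 2-(tert-butoxycarbonyl)ethyl on a saturated chain carbon bound to an amine nitrogen in a ring gives a 1.3-fold lower number from compound 2 to compound 4 (0.10 log units; within the scatter) at this position. The ester chain can therefore give way to the smaller ring-bearing group with no change beyond the scatter, so the ester is not required to keep the number of compound 2. Nothing here gives a reason for this result. The compounds shown leave open whether a carboxylic acid at the end of the chain, or a plain longer alkyl chain, would read the same.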